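A few compounds are considered here, and "the series" means these few. Any claim that something is new, unique, unknown or untested is made for them only; others in the source may bear on it.

Measured compounds in a functional assay on HCT-116 cells (Homo sapiens) for inhibition; a higher number here means a weaker inhibitor, a lower number a stronger inhibitor:
- compound 1 `COc1ccc(-c2coc(=O)n2-c2cc(OC)c(OC)c(OC)c2)cc1O` gives 1.7 nM
- compound 2 `COc1ccc(-c2coc(=O)n2-c2cc(OC)c(OC)c(OC)c2)cc1N` gives 3.2 nM
- compound 3 `COc1ccc(-c2oc(O)nc2-c2cc(OC)c(OC)c(OC)c2)cc1O` gives 6.1 nM

Compound 1 and compound 2 share one core and differ by amino in place of hydroxy on an aromatic carbon. That change gave a 1.9-fold higher number from compound 1 to compound 2 (0.27 log units; within the scatter). Compound 3 carries a second core, built from the same atoms joined differently; the difference between the two cores is not broken down here. Its number in this assay lies within the scatter of compound 2 and beyond the scatter of compound 1.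

Compound 4 `COc1ccc(-c2oc(O)nc2-c2cc(OC)c(OC)c(OC)c2)cc1N` is not yet measured. It differs from compound 3 by amino in place of hydroxy on an aromatic carbon, the same change as that from compound 1 to compound 2, at the same place. For compound 4 the step is expected to be a 1.8-fold higher number from compound 3 to compound 4 (0.26 log units; within the scatter), resting on compound 1 and compound 2 and their step of a 1.9-fold higher number from compound 1 to compound 2 (0.27 log units; within the scatter). Compound 4 is therefore estimated at 11 nM, likely between 5 nM and 25 nM.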

Compound 4, half-maximal inhibitory concentration: 3.7 nM
The estimate for compound 4 lay 3.0-fold (0.47 log units) above the measured number, and the stated range ends above it.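

In this assay, amino in place of hydroxy on the core of compound 3 gave a 1.6-fold lower number from compound 3 to compound 4 (0.22 log units; within the scatter). Each step on its own is within the scatter, yet set side by side the two differ: the same change on two cores in this assay, a 1.9-fold higher number (0.27 log units; within the scatter) from compound 1 to compound 2 and a 1.6-fold lower number (0.22 log units; within the scatter) from compound 3 to compound 4, 3.1-fold (0.49 log units) apart, beyond the scatter of two such steps In this series, then, the step on one core did not predict the step on the other, but with one pair on each core this does not show why they differ or how the change would behave on any further core.

Still open, as far as these compounds go, is whether a carboxylic acid or a dimethylamino group in place of the hydroxy would show the same gap between the two cores. A single assay also leaves open whether the gap appears in other cell lines.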